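A Methyl Group and Stability in Human Liver Microsomes

A few compounds are considered here, and "the series" means these few. Any claim that something is new, unique, unknown or untested is made for them only; others in the source may bear on it.

Four related compounds share a carbamate-bearing core and a (2-amino-2,4-dimethylpentyl)oxy chain, and three of them have been tested in an ADME assay on microsomes from liver (Homo sapiens) for metabolic stability, read by LC-MS, using NADPH, with a stated time of 10 min, tested at 0.5 uM; on this read-out higher numbers stand for a more stable compound and lower numbers for a less stable compound. Compound 1 `COC(=O)Nc1cc(-c2ccc(OC[C@@](C)(N)CC(C)C)cn2)ccn1` gives 93% in this assay. Compound 3 `COC(=O)Nc1cc(-c2cc(C)c(OC[C@@](C)(N)CC(C)C)cn2)ccn1` carries one extra methyl group, the change being (methyl in place of hydrogen on an aromatic carbon), and in this assay compound 3 gives 100%. The step of a number 7 percentage points higher from compound 1 to compound 3 (within the scatter) is therefore small. Compound 2 `COC(=O)Nc1cc(-c2ccc(OC[C@@](C)(N)CC(C)C)nc2)ccn1` has the same atoms as compound 1 joined in a different way; the difference between the two cores is not broken down here. In this assay compound 2 gives 100%.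

Compound 4 `COC(=O)Nc1cc(-c2cnc(OC[C@@](C)(N)CC(C)C)cc2C)ccn1` is not yet measured. It differs from compound 2 by methyl in place of hydrogen on an aromatic carbon. This is the same kind of change as from compound 1 to compound 3, but not the same: in compound 3 the methyl sits ortho to the (2-amino-2,4-dimethylpentyl)oxy group and meta to a large group, whereas in compound 4 it sits ortho to a large group and meta to the (2-amino-2,4-dimethylpentyl)oxy group. Since the measured step was a number 7 percentage points higher from compound 1 to compound 3 (within the scatter) and compound 2 already stands at 100%, little room for change is expected, and a step of about a number 3 percentage points lower from compound 2 to compound 4 (within the scatter) is estimated. Compound 4 is expected to give around 97% in this assay, likely between 87% and 100%.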

Compound 4, percent of the compound remaining: 98%
Beside the measured number, compound 4's estimate is 1 percentage points below it; low and high end bracket the measured number.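

On the second core, methyl in place of hydrogen on an aromatic carbon gives a number 2 percentage points lower from compound 2 to compound 4 (within the scatter) in this assay, so here the change has no effect that can be told apart from the scatter of repeated measurements. Set beside the earlier step, the result on this core does not differ from the result on the first by more than the scatter allows: the same change on two cores in this assay, a number 7 percentage points higher (within the scatter) from compound 1 to compound 3 and a number 2 percentage points lower (within the scatter) from compound 2 to compound 4, 9 percentage points apart, within the scatter of two such steps. This shows that, on these two cores, the methyl leaves the percent of compound remaining high, but it does not show that the change would behave alike on other cores, since the methyl sits in a different place on each of these two and all four values lie so near the top of the scale that any real difference would have little room to appear.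

The compounds shown leave open whether a different group on the same aromatic carbon, such as an ethyl, a fluorine or a methoxy group, would keep the compound as stable as the methyl does. They also leave open what a methyl would do on a less stable member of the series, where a rise or a fall could show more clearly.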